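Cytotoxicity of aroylhydrazones on WI-38 cells: next compound

The source may report more compounds than this note shows. Statements on the series, on what has been measured and on what is new or still open speak of the compounds shown alone.

Compound 1 `COc1ccc(/C=N/NC(=O)c2ccc(-c3cccc(Cl)c3)nc2C)cc1OC`: 168 ug/mL
Compound 2 `COc1ccc(/C=N/NC(=O)c2ccc(-c3ccc(Cl)cc3)nc2C)cc1`: 500 ug/mL
Compound 3 `Cc1nc(-c2ccc(Cl)cc2)ccc1C(=O)N/N=C/c1ccc(O)cc1`: 500 ug/mL

Three hydrazones have been measured in an ADME assay on WI-38 cells (Homo sapiens) for cytotoxicity, read by colorimetric assay and crystal violet staining, with a stated time of 24 h; a higher number here means a weaker inhibitor, a lower number a stronger inhibitor. Compound 3 gives 500 ug/mL, and stands level with compound 2 at the digits shown; together they give the highest numbers of the three. Within the data shown here, the only compound set apart is compound 1, whose value is lower than that of compound 3 by a gap beyond the scatter.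

The next compound, compound 4 `COc1cccc(/C=N/NC(=O)c2ccc(-c3ccc(Cl)cc3)nc2C)c1O`, is derived from compound 3 by the change (2-hydroxy-3-methoxyphenyl in place of 4-hydroxyphenyl on a carbon with a double bond to nitrogen). Among the measured compounds shown here, the one measured step that touches the same part of the molecule, no change at the digits printed from compound 2 to compound 3 (within the scatter), shows that swapping hydrogen for methyl on the ring oxygen left the number where it was. For the measured compounds named here, no measured step shows a hydroxyl and a methoxy group entering together on that ring. Compound 1 carries two methoxy groups and a lower number, but it also differs in its chlorophenyl group, so its value cannot be read as a step. The step of a 1.4-fold lower number from compound 3 to compound 4 (0.15 log units; within the scatter) is therefore expected to be small or none beyond the scatter, with a modest lean toward a lower number. Compound 4 is estimated at 350 ug/mL, within a range from 120 ug/mL to 600 ug/mL.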

Compound 4, half-maximal inhibitory concentration: 500 ug/mL
Estimate against measurement, compound 4: 1.4-fold (0.15 log units) below, within the range that was stated.
By their numbers in this assay, from the lowest: compound 1; then compounds 2, 3 and 4 (each within the scatter of the next).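

In this assay the change to 2-hydroxy-3-methoxyphenyl in place of 4-hydroxyphenyl gives no change at the digits printed from compound 3 to compound 4 (within the scatter) and the same group in place of 4-methoxyphenyl gives no change at the digits printed from compound 2 to compound 4 (within the scatter) on the carbon with a double bond to nitrogen. Until now this position had shown only hydrogen in place of methyl on a ring oxygen, whereas a ring carrying a hydroxyl and a methoxy group together now also leaves the number in place, so compounds 2, 3 and 4 stand within the scatter of one another. Nothing measured offers an explanation for this sameness.

Going by these compounds, it remains open whether an amine or a carboxylic acid on this ring would shift the number, as every ring here carries only hydroxyl or methoxy groups. Compound 1 differs from these compounds in more than one place, so the source of its lower number stays unresolved.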